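Amide-nitrogen swap from compound 2 to compound 3

The source may hold more compounds than are shown below. What is called first, only, known or untested is meant among the compounds shown, and "the series" means these compounds.

In a functional assay on HCT-116 cells (Homo sapiens) for cytotoxicity, read by sulforhodamine B assay, with a stated time of 72 h (on this read-out lower numbers stand for stronger inhibition and higher numbers for weaker inhibition), compound 2 (`Cc1ccc(-c2cc(C(=O)NCc3cccnc3)nn2-c2ccc3ccccc3n2)cc1`) gives 11200 nM and compound 1 (`Cc1ccc(-c2cc(C(=O)Nc3ccc(Cl)nc3Cl)nn2-c2ccc3ccccc3n2)cc1`) gives 7900 nM with the two values within the scatter of each other. Compound 3 (`Cc1ccc(-c2cc(C(=O)Nc3ncc(Br)cc3Br)nn2-c2ccc3ccccc3n2)cc1`) has 3,5-dibromopyridin-2-yl in place of (pyridin-3-yl)methyl on an amide-type nitrogen. Going by the values given here, the one measured step at that nitrogen (a 1.4-fold higher number from compound 1 to compound 2 (0.15 log units; within the scatter)) lay within the scatter, so no change beyond the scatter is expected in this assay for this swap. The estimated move (a 1.6-fold lower number from compound 2 to compound 3 (0.20 log units; within the scatter)) is therefore small and slightly toward a lower number. Compound 3 is estimated at 7000 nM with an expected range of 2500 nM to 16000 nM for repeated measurements.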

Compound 3, half-maximal inhibitory concentration: 9600 nM
Compound 3: middle estimate off by 1.4-fold (0.14 log units), on the low side; low and high end bracket the measured number.
By their numbers in this assay, from the lowest: compounds 1, 3 and 2 (each within the scatter of the next).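

In this assay, 3,5-dibromopyridin-2-yl on the amide-type nitrogen gives little movement against either earlier group (a 1.2-fold lower number from compound 2 to compound 3 (0.07 log units; within the scatter); a 1.2-fold higher number from compound 1 to compound 3 (0.08 log units; within the scatter)). A third group at this nitrogen, now with two bromines on the ring, therefore adds no separation, and all three compounds remain within the scatter of one another. No measurement is available that bears on this result. Still open, on these data alone, is whether any group at this nitrogen can move the number beyond the scatter, for instance a plain alkyl chain or a morpholine ring.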